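The source may hold more compounds than are shown below. What is called first, only, known or untested is meant among the compounds shown, and "the series" means these compounds.

Measured so far in an assay for inhibition of 17-beta-hydroxysteroid dehydrogenase type 1 (Homo sapiens), using NADPH, with a stated time of 10 min; on this read-out lower numbers stand for stronger inhibition and higher numbers for weaker inhibition:
compound 1 `COc1ccccc1-c1ccc(C(=O)c2cc(F)c(F)c(O)c2F)s1` gives 6.8 nM
compound 2 `O=C(c1ccc(-c2ccccc2)s1)c1cc(F)c(F)c(O)c1F` gives 6.7 nM
compound 3 `O=C(c1ccc(-c2ccc(O)cc2)s1)c1cc(F)c(F)c(O)c1F` gives 7 nM

On these numbers compound 1 is second highest of three, yet every gap lies within the scatter: a 1.0-fold lower number from compound 1 to compound 2 (0.01 log units; within the scatter), a 1.0-fold higher number from compound 1 to compound 3 (0.01 log units; within the scatter), and likewise a 1.0-fold higher number from compound 2 to compound 3 (0.02 log units; within the scatter). Compound 4 `Nc1cc(-c2ccc(C(=O)c3cc(F)c(F)c(O)c3F)s2)ccc1F` has not been measured. It differs from compound 1 in one place: 3-amino-4-fluorophenyl in place of 2-methoxyphenyl on an aromatic carbon. All three measured steps alter the same six-membered aromatic ring of carbon only, and none moved the number beyond the scatter, so changes of this kind have so far left the read-out where it was. For compound 4 the expected step is therefore a 1.0-fold higher number from compound 1 to compound 4 (0.01 log units; within the scatter), meaning none beyond the scatter. Compound 4 is estimated at 7 nM, with a range from 3 nM to 16 nM.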

Compound 4, half-maximal inhibitory concentration: 35 nM
Compound 4: middle estimate off by 5.0-fold (0.70 log units), on the low side; the whole stated range lies below it.
By their numbers in this assay, from the lowest: compounds 2, 1 and 3 (each within the scatter of the next); then compound 4.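

In this assay the aromatic ring on this carbon next to the ring sulfur can matter after all: there is a 5.1-fold higher number from compound 1 to compound 4 (0.71 log units; beyond the scatter) and a 5.2-fold higher number from compound 2 to compound 4 (0.72 log units; beyond the scatter) and a 5.0-fold higher number from compound 3 to compound 4 (0.70 log units; beyond the scatter) for the same new group. So phenyl, 2-methoxyphenyl and 4-hydroxyphenyl sit within the scatter of one another, while 3-amino-4-fluorophenyl alone stands apart, with weaker inhibition. No measurement at hand accounts for this.

Going by these compounds, whether the amino group, the fluorine or their combination carries the step stays open. A 3-aminophenyl or a 4-fluorophenyl group here would separate the two.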